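The compounds below may be only part of what the source reports. "The series", "measured", "known", "first", "only" and "open" are said of these compounds alone.

Measured compounds:
compound 1 `C#CCOc1ccc(C(CC(=O)c2cccc(C)c2)CC(=O)c2cccc(C)c2)cc1OC` — > 50000 nM
compound 2 `C=CCOc1ccc(/C=C/C(=O)c2ccc(OCC=C(C)C)c(CC=C)c2)cc1OC` — > 50000 nM
compound 3 `C=CCOc1ccc(C=O)cc1OC` — 14000 nM

In a functional assay on CCRF-CEM cells (Homo sapiens) for cytotoxicity, with a stated time of 72 h (a higher number here means a weaker inhibitor, a lower number a stronger inhibitor), compound 2 gives only a limit, > 50000 nM, and not a number. Compound 1 likewise returns only a limit in this assay, > 50000 nM. The one numerical result among the three belongs to compound 3, which gives 14000 nM in this assay. Two of the three results therefore sit at the limit of > 50000 nM in this assay, at which 2 of the 3 values shown sit, and compound 2 is one of them.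

Compound 4 `C#CCOc1ccc(C(=O)/C=C/c2ccc(OCC=C)c(OC)c2)cc1CC=C` has not yet been tested in this assay. It differs from compound 2 in one place: ethynyl in place of 2-methylprop-1-en-1-yl on a saturated chain carbon bound to an oxygen on an aromatic ring. Compound 1 already carries the propargyloxy group and still returns only a limit, so no basis is seen for expecting a gain in this assay. The step from compound 2 to compound 4 is expected to be a number no higher from compound 2 to compound 4 (the limit leaves the size open), that is none beyond the scatter. Compound 4 is estimated at 50000 nM in this assay, with a range from 15000 nM to 150000 nM, and it may well again come back as a limit only.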

Compound 4, half-maximal inhibitory concentration: > 50000 nM
Compound 4 ended at the assay's limit; the forecaster's own chance of this, stated with the estimate: 65%; the middle value lies on the limit itself.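

Compound 2 and compound 4 both return only a limit in this assay, so no step between them can be read: the limit of > 50000 nM in this assay, at which 3 of the 4 values shown sit.

The compounds shown leave open whether ethynyl in place of 2-methylprop-1-en-1-yl changes the result in this assay at all, and by how much.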